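The source may report more compounds than this note shows. Statements on the series, on what has been measured and on what is new or still open speak of the compounds shown alone.

In a physicochemical assay for solubility, with a stated time of 24 h, at pH 4.5 (on this read-out lower numbers stand for lower solubility and higher numbers for higher solubility), compound 3 `O=C(NC[C@@H]1[C@H]2CN(C(=O)CCc3cc(Cl)cc(Cl)c3)C[C@@H]12)c1ccc2[nH]c(=O)oc2c1` gives < 1 ug/mL, which is a limit and not a number. Compound 1 `O=C(NC[C@@H]1[C@H]2CN(C(=O)OCc3cc(Cl)cc(Cl)c3)C[C@@H]12)c1ccc2[nH]c(=O)oc2c1` gives < 1 ug/mL, also a limit. Compound 2 `O=C(NC[C@@H]1[C@H]2CN(C(=O)/C=C/c3cc(Cl)cc(Cl)c3)C[C@@H]12)c1ccc2[nH]c(=O)oc2c1` gives < 1 ug/mL, again a limit. Compound 4 `O=C(NC[C@@H]1[C@H]2CN(C(=O)C3CC3c3cc(Cl)cc(Cl)c3)C[C@@H]12)c1ccc2[nH]c(=O)oc2c1` differs from compound 3 in one place: a group of 11 heavy atoms (9 carbon, 2 chlorine; one three-membered non-aromatic ring of carbon only, one six-membered aromatic ring of carbon only) in place of a group of 10 heavy atoms (8 carbon, 2 chlorine; one six-membered aromatic ring of carbon only), on a carbonyl carbon. The measured changes at this same carbonyl carbon are a step that the two limits leave unreadable from compound 1 to compound 2, a step that the two limits leave unreadable from compound 1 to compound 3 and a step that the two limits leave unreadable from compound 2 to compound 3, so none has a size that can be read. Together these compounds show (the limit of < 1 ug/mL in this assay, at which 3 of the 3 values shown sit). These steps point in no direction, so no change beyond the usual scatter is expected, and the estimated move is a step that the limit leaves unreadable from compound 3 to compound 4. For compound 4 the estimated value is 0.5 ug/mL, with an expected range of 0.2 ug/mL to 1.2 ug/mL.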

Compound 4, solubility: < 1 ug/mL
Compound 4 was reported as a limit; the forecaster's own chance of this, stated with the estimate: 90%; the middle value is on the limit's open side.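

Within the data shown here, compound 1, compound 2, compound 3 and compound 4 all stand at the same limit, so no step among them can be read: the limit of < 1 ug/mL in this assay, at which 4 of the 4 values shown sit. The compounds shown leave open how their true values compare, and whether any of these groups on the carbonyl carbon changes the read-out at all.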